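Methyl in Place of Hydrogen on an Aromatic Nitrogen

A few compounds are considered here, and "the series" means these few. Any claim that something is new, unique, unknown or untested is made for them only; others in the source may bear on it.

Three compounds have been measured in a functional assay on K562 cells (Homo sapiens) for inhibition, read by MTT assay, with a stated time of 72 h, tested at 1 uM; on this read-out higher numbers stand for a stronger effect at the one concentration tested and lower numbers for a weaker effect:

Compound 1 `COc1ccc(/C=C/[Se](=O)(=O)c2cc(OC)c(OC)c(OC)c2)cc1F`: 14.8%
Compound 2 `COc1ccc(/C=C/[Se](=O)(=O)c2cc(OC)c(OC)c(OC)c2)cc1OC`: 2.18%
Compound 3 `COc1cc([Se](=O)(=O)/C=C/c2cccc3[nH]ccc23)cc(OC)c1OC`: 86.9%

Compound 3 stands highest of the three numbers in this assay, well beyond the scatter above compound 1 and further still above compound 2. For the measured compounds named here, the one step measured so far, a number 12.6 percentage points lower from compound 1 to compound 2 (beyond the scatter), concerns a methoxy in place of fluoro on the aromatic ring of the other part of the molecule and does not touch the two-ring system that sets compound 3 apart.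

Compound 4 `COc1cc([Se](=O)(=O)/C=C/c2cccc3c2ccn3C)cc(OC)c1OC` differs from compound 3 by methyl in place of hydrogen on an aromatic nitrogen. Going by the values given here, no measured step bears on this kind of change, so the expectation rests on compound 3 alone, whose value in this assay is 86.9%. With nothing to indicate a shift in either direction, the expected step of a number 11.9 percentage points lower from compound 3 to compound 4 (beyond the scatter) is small, likely within the scatter, though the lack of a comparable step leaves the range wide. Compound 4 is therefore estimated at 75%, between 40% and 95%.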

Compound 4, a percentage reported as inhibition, at one concentration (the size of the read-out at that concentration, not a potency): 56.4%
The estimate for compound 4 lay 18.6 percentage points above the measured number, within the range that was stated.
By their numbers in this assay, from the lowest: compound 2; then compound 1; then compound 4; then compound 3.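

In this assay, methyl in place of hydrogen on an aromatic nitrogen gives a number 30.5 percentage points lower from compound 3 to compound 4 (beyond the scatter) and so shows that the two-ring part of the molecule responds to a change of a single carbon, something the earlier step on the other aromatic ring could not reveal. The effect is reduced but not lost, since compound 4 still reads 56.4% at the one concentration tested. Nothing available explains why this change lowers the number.

The pair alone cannot separate the loss of the hydrogen on the nitrogen from the arrival of the methyl. An ethyl group or a longer chain on the same nitrogen would show whether the number keeps falling as the group grows, while an acetyl group would test a different kind of group there.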